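From 2-Fluorophenyl to 4-Methylphenyl on the Amide

The source may report more compounds than this note shows. Statements on the series, on what has been measured and on what is new or still open speak of the compounds shown alone.

Four compounds share one core and differ only in the aromatic group on an amide-type nitrogen: compound 1 (`CN(C)C(=O)c1cc2cnc(Nc3ccc(NC(=O)C4(C(=O)Nc5ccc(F)cc5)CC4)cc3)nc2n1C1CCCC1`), compound 2 (`CN(C)C(=O)c1cc2cnc(Nc3ccc(NC(=O)C4(C(=O)Nc5cccc(O)c5)CC4)cc3)nc2n1C1CCCC1`), compound 3 (`CN(C)C(=O)c1cc2cnc(Nc3ccc(NC(=O)C4(C(=O)Nc5ccccc5F)CC4)cc3)nc2n1C1CCCC1`) and the still unmeasured compound 4 (`Cc1ccc(NC(=O)C2(C(=O)Nc3ccc(Nc4ncc5cc(C(=O)N(C)C)n(C6CCCC6)c5n4)cc3)CC2)cc1`). In a functional assay on SiHa cells (Homo sapiens) for inhibition, read by CCK-8 assay, with a stated time of 72 h, tested at 1 uM (on this read-out higher numbers stand for more inhibition of growth at the one concentration tested and lower numbers for less inhibition of growth), compound 3 gives 63.4%, the highest of the three numbers, while compound 1 gives 36.5% and compound 2 gives -19.8%.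

The next change is 4-methylphenyl in place of 2-fluorophenyl on an amide-type nitrogen. For the measured compounds named here, no measured compound carries 4-methylphenyl, so the evidence is indirect. The nearest guide is compound 1, with its 4-fluorophenyl, and a number 26.9 percentage points higher from compound 1 to compound 3 (beyond the scatter) is a modest step. Read in reverse, it suggests that compound 4 may lose part of the number held by compound 3. Compound 2 is a weaker guide, since its 3-hydroxyphenyl resembles the entering group less, but a number 56.3 percentage points lower from compound 1 to compound 2 (beyond the scatter) warns that this assay can move by a large step when this group alone changes.

A modest fall is therefore expected, and the estimated step is a number 25.4 percentage points lower from compound 3 to compound 4 (beyond the scatter). For compound 4 the expected value is 38%, with an estimated range from 8% to 66%.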

Compound 4, percent growth inhibition at one concentration: 37%
Compound 4: middle estimate off by 1 percentage points, on the high side, and the stated range covers the measured number.
By their numbers in this assay, from the lowest: compound 2; then compounds 1 and 4 (each within the scatter of the next); then compound 3.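

In this assay methyl in place of fluoro on an aromatic carbon gives a number 0.5 percentage points higher from compound 1 to compound 4 (within the scatter) and so does not separate 4-methylphenyl from 4-fluorophenyl on this amide-type nitrogen. Replacing 2-fluorophenyl with 4-methylphenyl gives a number 26.4 percentage points lower from compound 3 to compound 4 (beyond the scatter) while replacing 3-hydroxyphenyl with it gives a number 56.8 percentage points higher from compound 2 to compound 4 (beyond the scatter) and these two steps place compound 1 and compound 4 together on a level between compound 2 and compound 3, so among these four aromatic groups the number changes when the group on the ring changes its printed place or becomes hydroxy, but not when fluoro gives way to methyl on the 4-substituted ring. Nothing given here accounts for these differences.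

Going by these compounds, what remains open is whether the high number of compound 3 goes with fluoro itself or with the 2-position, which a 2-methylphenyl or 2-chlorophenyl group on the same nitrogen would help to separate. Likewise, a 3-fluorophenyl or 4-hydroxyphenyl group would help to show whether the low number of compound 2 follows the hydroxyl group or its place on the ring.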